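Taking the phosphate group off compound 2

The source may hold more compounds than are shown below. What is called first, only, known or untested is meant among the compounds shown, and "the series" means these compounds.

In a functional assay on HeLa cells (Homo sapiens) for antiproliferative activity, read by fluorescence and resazurin assay, with a stated time of 48 h (on this read-out lower numbers stand for an effect already at smaller amounts and higher numbers for an effect only at larger amounts of compound), compound 1 (`COc1cc(-c2nccc3c(OC)c(OC)c(OC)cc23)ccc1O`) gives 50000 nM. Compound 2 (`COc1cc(-c2nccc3c(OC)c(OC)c(OC)cc23)ccc1OP(=O)(O)O`) returns only a limit, > 100000 nM, and so stands at the limit of > 100000 nM in this assay, at which 1 of the 2 values shown sits. Compound 3 (`COc1cccc(-c2nccc3c(OC)c(OC)c(OC)cc23)c1`) differs from compound 2 by a hydrogen atom in place of a group of 5 heavy atoms (4 oxygen, 1 phosphorus; no ring), on an aromatic carbon. Going by the values given here, the one measured step bearing on this change is an at least 2.0-fold higher number from compound 1 to compound 2 (0.30 log units; that floor lies within the scatter). On that step alone, a lower number is expected in this assay for compound 3, towards compound 1 at 50000 nM. The expected move is an at least 2.5-fold lower number from compound 2 to compound 3 (0.39 log units; beyond the scatter). For compound 3 the estimated value is 40000 nM, with an expected range of 12000 nM to 100000 nM.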

Compound 3, half-maximal effective concentration: 15000 nM
The estimate for compound 3 lay 2.7-fold (0.43 log units) above the measured number, and the stated range covers the measured number.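

In this assay, the aromatic carbon para to a large group carries no requirement for either oxygen substituent: hydrogen replacing the phosphate-bearing group gives an at least 6.6-fold lower number from compound 2 to compound 3 (0.82 log units; beyond the scatter), and hydrogen replacing hydroxy gives a 3.3-fold lower number from compound 1 to compound 3 (0.52 log units; beyond the scatter). Compound 3 therefore has the lowest number of the three, with both steps beyond the scatter. The reading for compound 2 is only a limit, so the first step is a floor: the limit of > 100000 nM in this assay, at which 1 of the 3 values shown sits.

Still open, as far as these compounds go, is whether an amine, a carboxylic acid or fluorine on this carbon would shift the number further from that of compound 3. From the compounds shown here alone, the role of the methoxy group on the same ring also remains open.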